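A few compounds are considered here, and "the series" means these few. Any claim that something is new, unique, unknown or untested is made for them only; others in the source may bear on it.

In a functional assay with Homo sapiens as the target (a higher number here means a weaker inhibitor, a lower number a stronger inhibitor), compound 1 `CC(C)[C@H](NC(=O)COc1cccc2ccccc12)C(=O)N[C@@H](CC(=O)O)C(=O)COc1ccccc1C(F)(F)F` gives 17300 nM and compound 2 `CC(C)[C@H](NC(=O)COc1cccc2ccccc12)C(=O)N[C@@H](CC(=O)O)C(=O)COc1ccc(F)c(F)c1` gives 16200 nM so the two stand level within the usual scatter. Compound 3 `CC(C)[C@H](NC(=O)COc1cccc2ccccc12)C(=O)N[C@@H](CC(=O)O)C(=O)COc1cc(F)cc(F)c1` carries the change 3,5-difluorophenyl in place of 3,4-difluorophenyl on an oxygen on a saturated carbon in which 3,5-difluorophenyl stands in place of 3,4-difluorophenyl on an oxygen on a saturated carbon. Among the measured compounds shown here, the one measured step at that place a 1.1-fold lower number from compound 1 to compound 2 (0.03 log units; within the scatter) stayed within the scatter, and it is only a single step to go on. In this assay the expected 1.0-fold lower number from compound 2 to compound 3 (0.01 log units; within the scatter) is therefore nothing beyond the scatter. Compound 3 is estimated at 16000 nM within an expected range of 7500 nM to 34000 nM.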

Compound 3, half-maximal inhibitory concentration: 15900 nM
The estimate for compound 3 lay 1.0-fold (0.00 log units) above the measured number, within the range that was stated.
By their numbers in this assay, from the lowest: compounds 3, 2 and 1 (each within the scatter of the next).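

In this assay, 3,5-difluorophenyl in place of 3,4-difluorophenyl gives a 1.0-fold lower number from compound 2 to compound 3 (0.01 log units; within the scatter) and so shows that rearranging the same atoms at this place leaves the number level. The comparison with 2-(trifluoromethyl)phenyl gives a 1.1-fold lower number from compound 1 to compound 3 (0.04 log units; within the scatter) and so all three ring groups on this oxygen now read alike. No evidence here explains this sameness. From the compounds shown here alone, whether it would hold for a phenyl ring carrying an amine or a nitrile, or for a longer chain in place of the ring, stays open.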